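The compounds below may be only part of what the source reports. "The series", "measured", "known", "first", "only" and "open" are said of these compounds alone.

Of the compounds shown here, three built on one shared core have been tested in a functional assay on MV4-11 cells (Homo sapiens) for antiproliferative activity, read by CCK-8 assay, with a stated time of 72 h; on this read-out higher numbers stand for weaker inhibition and lower numbers for stronger inhibition. Compound 1 `Cn1cc(-c2ccccc2)c2cc(C(=O)NCc3ccc(C(=O)Nc4ccccc4N)cc3)[nH]c2c1=O` gives 230 nM; compound 2 `CC(C)Oc1ccccc1-c1cn(C)c(=O)c2[nH]c(C(=O)NCc3ccc(C(=O)Nc4ccccc4N)cc3)cc12` gives 130 nM; and compound 3 `Cc1ccccc1-c1cn(C)c(=O)c2[nH]c(C(=O)NCc3ccc(C(=O)Nc4ccccc4N)cc3)cc12` gives 310 nM. Compound 3 carries the highest of the three numbers, yet a 1.3-fold higher number from compound 1 to compound 3 (0.13 log units; within the scatter) lies within the scatter, and only a 2.4-fold higher number from compound 2 to compound 3 (0.38 log units; beyond the scatter), a modest step, sets compound 3 apart from another member of the set.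

Compound 4 `Cn1cc(-c2cccc(Cl)c2)c2cc(C(=O)NCc3ccc(C(=O)Nc4ccccc4N)cc3)[nH]c2c1=O` has not been measured. It differs from compound 3 in a single place: 3-chlorophenyl in place of 2-methylphenyl on an aromatic carbon. Going by the values given here, no measured step exchanges one substituted phenyl for another, so the guidance is indirect. Among the compounds with values here, the closest steps are a 1.3-fold higher number from compound 1 to compound 3 (0.13 log units; within the scatter) and a 1.8-fold lower number from compound 1 to compound 2 (0.25 log units; within the scatter), both within the scatter, which show that adding a methyl or an isopropoxy to the bare phenyl of compound 1 hardly shifted this assay, while a 2.4-fold higher number from compound 2 to compound 3 (0.38 log units; beyond the scatter) is the only step beyond it. On that basis the move to 3-chlorophenyl is expected to leave the number close to those of compound 1 and compound 3, with no step beyond the scatter anticipated, and the expected step is a 1.3-fold lower number from compound 3 to compound 4 (0.13 log units; within the scatter). Compound 4 is therefore estimated at 230 nM, with a range from 100 nM to 520 nM.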

Compound 4, half-maximal inhibitory concentration: 190 nM
For compound 4 the middle estimate is 1.2-fold (0.08 log units) above the measured one, within the range that was stated.
By their numbers in this assay, from the lowest: compounds 2, 4, 1 and 3 (each within the scatter of the next, the first and the last beyond it).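

Going by these compounds alone, replacing the substituted phenyl with 3-chlorophenyl gives the first chloro group at this position and the first substituent on this phenyl that is not 2-methyl or 2-isopropoxy, and in this assay none of the three new steps leaves the scatter: a 1.2-fold lower number from compound 1 to compound 4 (0.08 log units; within the scatter), a 1.6-fold lower number from compound 3 to compound 4 (0.21 log units; within the scatter) and a 1.5-fold higher number from compound 2 to compound 4 (0.16 log units; within the scatter). The position therefore accepts this exchange of one substituted phenyl for another, as well as the addition of chloro to the bare phenyl, without a step that can be told from repeat variation, and compound 4 falls within the scatter of the two compounds that are separated from each other, compound 2 and compound 3. Nothing available explains these small differences, so the result records their size and gives no cause.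

The compounds shown leave open how chloro would read on another carbon of the phenyl, so the effect of substituent location cannot be separated from that of substituent identity. They also leave open whether a phenyl bearing an amine or a carboxylic acid, or a longer alkoxy chain in place of the isopropoxy, would produce a step beyond the scatter.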